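Two Measured Compounds and a Chloro-for-Methoxy Step

The source may report more compounds than this note shows. Statements on the series, on what has been measured and on what is new or still open speak of the compounds shown alone.

The study concerns a shared core carrying two substituted aromatic rings. Compound 1 `O=C1/C(=C/c2ccc(Cl)cc2)CCC/C1=C\c1ccc([N+](=O)[O-])cc1` bears a 4-chlorophenyl group and a nitrophenyl group; in a functional assay on MOLT-4 cells (Homo sapiens) for cytotoxicity, with a stated time of 72 h (a higher number here means a weaker inhibitor, a lower number a stronger inhibitor), compound 1 gives 9120 nM. Compound 2 `COc1ccc(/C=C2\CCC/C(=C\c3ccccc3[N+](=O)[O-])C2=O)cc1` carries a 4-methoxyphenyl group instead, with the nitro group placed differently on the other ring; in this assay compound 2 gives 8900 nM. These two numbers lie so close together that the difference falls within the scatter of repeated measurements, so neither compound can be called stronger or weaker than the other.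

Compound 3 `O=C1/C(=C/c2ccc(Cl)cc2)CCC/C1=C\c1ccccc1[N+](=O)[O-]` has not yet been measured. It differs from compound 2 in one place: chloro in place of methoxy on an aromatic carbon. Because compound 1 gives 9120 nM with the same 4-chlorophenyl group, and compound 2 gives 8900 nM with the methoxy, no step beyond the scatter is expected from this change in this assay, and the estimated step of a 1.0-fold higher number from compound 2 to compound 3 (0.00 log units; within the scatter) is essentially flat. Compound 3 is therefore expected to give about 9000 nM, within a range from 4000 nM to 20000 nM.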

Compound 3, half-maximal inhibitory concentration: 3860 nM
Compound 3: the middle estimate sits 2.3-fold (0.37 log units) above what was measured, outside the stated range (below it).
By their numbers in this assay, from the lowest: compound 3; then compounds 2 and 1 (each within the scatter of the next).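

In this assay, chloro in place of methoxy, on an aromatic carbon para to a large group, gives a 2.3-fold lower number from compound 2 to compound 3 (0.36 log units; beyond the scatter) and so makes compound 3 a modestly stronger inhibitor than compound 2. For the compounds shown here, this is the first reading of that change alone, since compound 1 and compound 2 differ in two places at once and their close values could not separate the contribution of either place. No measurement here gives a reason for the step, so it stands as an observed difference in cytotoxicity and nothing more.

The compounds shown leave open whether the same change would have a similar effect with the nitro group placed as in compound 1, because this single pair cannot show whether the step carries over to another setting. They also leave open how other groups at this place would compare, such as a fluoro group, a methyl group, a dimethylamino group or a carboxylic acid, and so whether the step marks the start of a wider trend or is specific to chloro.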